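Expected Cytotoxicity After a Side-Chain Replacement

The compounds below may be only part of what the source reports. "The series", "measured", "known", "first", "only" and "open" are said of these compounds alone.

Of the compounds shown here, two have been tested in an ADME assay on HepG2 2.2.15 cells (Homo sapiens) for cytotoxicity; on this read-out lower numbers stand for higher toxicity in this test and higher numbers for lower toxicity in this test. Compound 1 `O=C(CCCCC(=O)Nc1ncc(Cc2ccc(F)cc2)s1)Nc1ncc(Cc2ccc(F)cc2)s1` gives > 50000 nM in this assay, which is a limit of the test rather than a number. Compound 2 `COC(=O)CCCCNc1ncc(C(Oc2ccc3cc(Br)ccc3c2)c2ccc(Cl)cc2)s1` is recorded in this assay as "not toxic" (no number reported), with no number attached. Taken together the two results agree: one stands at the limit of > 50000 nM in this assay, at which 1 of the 2 values shown sits, and the other is a word only. Compound 2 therefore sits at the least toxic end of what this test can show.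

Compound 3 `Cc1noc(C)c1C(=O)Nc1ncc(C(Oc2ccc3cc(Br)ccc3c2)c2ccc(Cl)cc2)s1` differs from compound 2 in one place: (3,5-dimethyl-1,2-oxazol-4-yl)carbonyl in place of 4-(methoxycarbonyl)butyl on a nitrogen on an aromatic ring. Going by the values given here, no measured pair shows this change, so its effect on this assay can only be expected, not read off. No shift beyond the usual scatter is expected in either direction, because compound 2 is recorded as "not toxic" (no number reported). Compound 3 is expected to give about 50000 nM in this assay, with a likely range from 20000 nM to 100000 nM.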

Compound 3, half-maximal cytotoxic concentration: "not toxic" (no number reported)
Compound 3 has no reported number here; there is nothing to compare the estimate with.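

In this assay compound 2 and compound 3 are both recorded only as "not toxic", with no number, so no step can be read between them. From the compounds shown here alone, whether replacing 4-(methoxycarbonyl)butyl with (3,5-dimethyl-1,2-oxazol-4-yl)carbonyl changes the half-maximal cytotoxic concentration at all remains open.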